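The compounds below may be only part of what the source reports. "The series", "measured", "known", "first", "only" and "open" are said of these compounds alone.

Of the compounds shown here, three have been measured so far in a functional assay on SH-SY5Y cells (Homo sapiens) for cytotoxicity, read by MTT assay, with stated times of 24 h and 4 h (on this read-out lower numbers stand for an effect already at smaller amounts and higher numbers for an effect only at larger amounts of compound), and a fourth is still waiting for its number. Compound 1 `COc1cc(CNC(=O)/C=C/c2cccc(OCc3nc(C)c(C)nc3C)c2)ccc1O` gives 8090 nM in this assay. Compound 2 `COc1cc(CNC(=O)/C=C/c2cccc(OCc3nc(C)c(C)nc3C)c2)ccc1OCc1nc(C)c(C)nc1C` gives 8700 nM. The two differ in a single place: (3,5,6-trimethylpyrazin-2-yl)methyl in place of hydrogen on an oxygen on an aromatic ring The step of a 1.1-fold higher number from compound 1 to compound 2 (0.03 log units; within the scatter) is therefore one that cannot be told apart from the ordinary spread of repeated measurements; on the core of compound 1 this change left the read-out where it was.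

Compound 3 `COc1cc(CNC(=O)/C=C/c2cc(OC)c(OC)cc2OC)ccc1O` gives 2410 nM, the lowest number of the three. Its gap to compound 1 and its gap to compound 2 both lie beyond the scatter, so compound 3 acts already at smaller amounts than either of them. The difference between the core of compound 3 and the core of compound 1 is not broken down here.

Compound 4 `COc1cc(OC)c(OC)cc1/C=C/C(=O)NCc1ccc(OCc2nc(C)c(C)nc2C)c(OC)c1` is the one not yet measured. For the measured compounds named here, it differs from compound 3 in one place: (3,5,6-trimethylpyrazin-2-yl)methyl in place of hydrogen on an oxygen on an aromatic ring This is the same change as the one from compound 1 to compound 2, made at the same kind of place on the ring oxygen. The step from compound 3 to compound 4 is expected to be about a 1.1-fold higher number from compound 3 to compound 4 (0.03 log units; within the scatter). That expectation rests on the earlier step having come out as a 1.1-fold higher number from compound 1 to compound 2 (0.03 log units; within the scatter), with nothing in the data to suggest the core of compound 3 would respond differently. Compound 4 is accordingly estimated at 2600 nM, with a likely range from 1200 nM to 5600 nM.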

Compound 4, half-maximal effective concentration: 3620 nM
Estimate against measurement, compound 4: 1.4-fold (0.14 log units) below; the measured number falls inside the stated range.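

In this assay, the new step is a 1.5-fold higher number from compound 3 to compound 4 (0.18 log units; within the scatter), so on this second core, as on the first, adding (3,5,6-trimethylpyrazin-2-yl)methyl to the ring oxygen produces no shift that can be told apart from the ordinary spread of repeated measurements. Set side by side, the two results agree, and in this small set the change carries from one core to the other without a detectable difference: the same change on two cores in this assay, a 1.1-fold higher number (0.03 log units; within the scatter) from compound 1 to compound 2 and a 1.5-fold higher number (0.18 log units; within the scatter) from compound 3 to compound 4, 1.4-fold (0.15 log units) apart, within the scatter of two such steps This is only one repeat of the change on two cores in a single cell assay, so it does not show that every core in the series would respond in the same way, nor does it explain why the read-out stays put.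

The compounds shown leave open whether a different group placed on the same oxygen, such as a plain benzyl group, a longer carbon chain, or a chain ending in an amine or a carboxylic acid, would also leave the number within the scatter. They also leave open whether the (3,5,6-trimethylpyrazin-2-yl)methyl group would behave this way on a core other than these two.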